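Replacing Neopentyl with Tert-Butoxy on a Carbonyl Carbon

The source may hold more compounds than are shown below. What is called first, only, known or untested is meant among the compounds shown, and "the series" means these compounds.

Measured compounds:
- compound 1 `Cn1cncc1CN1CC(N(CC2CCN(C(=O)CC(C)(C)C)CC2)S(=O)(=O)c2ccccn2)Cc2cc(C#N)ccc21`: 0.5 10^-6 cm/s
- compound 2 `C=C(C)C(=O)N1CCC(CN(C2Cc3cc(C#N)ccc3N(Cc3cncn3C)C2)S(=O)(=O)c2ccccn2)CC1`: 0.5 10^-6 cm/s
- compound 3 `Cn1cnc(S(=O)(=O)N(Cc2cccc(-n3cccc3)c2)C2Cc3cc(C#N)ccc3N(Cc3cncn3C)C2)c1`: 0.2 10^-6 cm/s

Of the compounds shown here, three built on a shared core have been tested in an ADME assay on Caco-2 cells (Homo sapiens) for permeability, in the apical to basolateral direction; on this read-out lower numbers stand for lower permeability and higher numbers for higher permeability. Compound 1 gives 0.5 10^-6 cm/s in this assay. Compound 2 stands level with it, and the two together hold the highest numbers of the three. Compound 3 sits furthest from compound 1, with a number lower by an amount beyond the scatter.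

Compound 4 `Cn1cncc1CN1CC(N(CC2CCN(C(=O)OC(C)(C)C)CC2)S(=O)(=O)c2ccccn2)Cc2cc(C#N)ccc21` has not yet been measured. It differs from compound 1 in one place: tert-butoxy in place of neopentyl on a carbonyl carbon.

Going by the values given here, only one measured step bears on this change. The step from compound 1 to compound 2 also alters the group on that same carbonyl carbon, and it gave no change at the digits printed from compound 1 to compound 2 (within the scatter). Among the compounds with values here, no measured step introduces an oxygen at this position, so the bearing is indirect. On that basis the change to compound 4 is expected to produce little or no step beyond the scatter, no change at the digits printed from compound 1 to compound 4 (within the scatter). Compound 4 is therefore estimated at 0.5 10^-6 cm/s, within a range of 0.2 10^-6 cm/s to 1.2 10^-6 cm/s.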

Compound 4, apparent permeability: 15.5 10^-6 cm/s
For compound 4 the middle estimate is 31-fold (1.49 log units) below the measured one; the whole stated range lies below it.
By their numbers in this assay, from the lowest: compound 3; then compounds 1 and 2 (each within the scatter of the next); then compound 4.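

In this assay the group on this carbonyl carbon turns out not to be a silent spot: tert-butoxy in place of neopentyl gives a 31-fold higher number from compound 1 to compound 4 (1.49 log units; beyond the scatter), although the two groups differ only by one oxygen taking the place of one carbon, which adds a hydrogen-bond acceptor. Tert-butoxy in place of 1-methylethenyl gives a 31-fold higher number from compound 2 to compound 4 (1.49 log units; beyond the scatter), so the flat result between compound 1 and compound 2 held for those two groups only and not for the position as a whole. Nothing in the data shown gives a reason for this jump.

From the compounds shown here alone, it remains open whether methoxy or a dimethylamino group on the same carbonyl carbon would behave like tert-butoxy or like neopentyl. Going by these compounds, it is equally open whether a single oxygen at this place is enough, or whether the full tert-butoxy group is needed.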